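The source may hold more compounds than are shown below. What is called first, only, known or untested is meant among the compounds shown, and "the series" means these compounds.

In a functional assay on MDA-MB-231 cells (Homo sapiens) for antiproliferative activity, read by MTT assay (on this read-out lower numbers stand for stronger inhibition and higher numbers for weaker inhibition), compound 2 (`COc1ccc([C@@H]2[C@@H](c3ccsc3)C(=O)N2c2cc(OC)c(OC)c(OC)c2)cc1O`) gives 49 nM and is the lowest of the three measured numbers. Compound 1 (`COc1ccc([C@@H]2[C@@H](c3cccs3)C(=O)N2c2cc(OC)c(OC)c(OC)c2)cc1N`) gives 110 nM and compound 3 (`COc1ccc([C@@H]2C(c3cccs3)C(=O)N2c2cc(OC)c(OC)c(OC)c2)cc1`) gives 190 nM and both lie beyond the scatter from compound 2. Compound 4 (`COc1ccc([C@@H]2[C@@H](c3cccs3)C(=O)N2c2cc(OC)c(OC)c(OC)c2)cc1O`) is still unmeasured. It carries thiophen-2-yl in place of thiophen-3-yl on a saturated ring carbon. Going by the values given here, no measured pair differs in one place alone, so the series offers no direct precedent for this exchange. In this assay no step beyond the scatter is expected, and neither direction is favoured. The expected change is a 1.2-fold higher number from compound 2 to compound 4 (0.09 log units; within the scatter) and remains a rough estimate. The estimated value for compound 4 is 60 nM with an expected range from 25 nM to 150 nM for repeat measurements.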

Compound 4, half-maximal inhibitory concentration: 180 nM
Estimate against measurement, compound 4: 3.0-fold (0.48 log units) below; the measured number lies above the stated range.
By their numbers in this assay, from the lowest: compound 2; then compounds 1, 4 and 3 (each within the scatter of the next).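

In this assay, the saturated ring carbon is sensitive to how the thiophene is attached: thiophen-2-yl in place of thiophen-3-yl gives a 3.7-fold higher number from compound 2 to compound 4 (0.57 log units; beyond the scatter), although both groups have the same heavy-atom and hydrogen-bond counts. With thiophen-2-yl held, hydroxy in place of amino on an aromatic carbon gives a 1.6-fold higher number from compound 1 to compound 4 (0.21 log units; within the scatter), which stays within the scatter. As far as these compounds go, whether thiophen-3-yl keeps its advantage with amino in place of hydroxy remains open, as does the standing of phenyl or furan-3-yl on the same carbon. No measurement at hand bears on what underlies the thiophen-2-yl step.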